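The source may hold more compounds than are shown below. What is called first, only, known or untested is meant among the compounds shown, and "the series" means these compounds.

Measured so far:
compound 1 `Nc1ccc(-c2cc(=O)c3c(N)c(F)c(C(=O)O)c(F)c3o2)cc1F` — in a functional assay on HeLa cells (Homo sapiens) for cytotoxicity, read by neutral red uptake, with a stated time of 3 days (a higher number here means a weaker inhibitor, a lower number a stronger inhibitor), compound 1 gives only a limit, > 100000 nM.
compound 2 `CCCOCc1c(F)c(N)c2c(=O)cc(-c3ccc(N)c(F)c3)oc2c1F` — in this assay compound 2 gives 78000 nM.

Going by the values given here, compound 2 holds the only number in the set. The other entry is a limit (the limit of > 100000 nM in this assay, at which 1 of the 2 values shown sits). Among the compounds with values here, the one measured step, an at least 1.2-fold lower number from compound 1 to compound 2 (0.10 log units; that floor lies within the scatter), concerns carboxy against propoxymethyl on an aromatic carbon and stays within the scatter.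

Compound 3 `NCc1c(F)c(N)c2c(=O)cc(-c3ccc(N)c(F)c3)oc2c1F` differs from compound 2 by amino in place of propoxy on a saturated chain carbon bound to an aromatic carbon. Within the data shown here, no measured step covers this kind of change; the series gives nothing that argues for a move beyond the scatter in either direction in this assay. The expected step of a 1.0-fold higher number from compound 2 to compound 3 (0.01 log units; within the scatter) is set near nil, with the range kept wide. Compound 3 is estimated at 80000 nM, between 30000 nM and 200000 nM.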

Compound 3, half-maximal inhibitory concentration: 8800 nM
Compound 3: the middle estimate sits 9.1-fold (0.96 log units) above what was measured; the whole stated range lies above it.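

On the saturated chain carbon bound to an aromatic carbon, the choice of group does register in this assay: amino in place of propoxy gives an 8.9-fold lower number from compound 2 to compound 3 (0.95 log units; beyond the scatter), whereas the earlier step at this place did not leave the scatter. Aminomethyl in place of carboxy on the aromatic carbon gives an at least 11-fold lower number from compound 1 to compound 3 (1.05 log units; beyond the scatter), so the position can move the read-out when the entering group is aminomethyl. That second step is only a floor, since the value of compound 1 is a limit: the limit of > 100000 nM in this assay, at which 1 of the 3 values shown sits.

As far as these compounds go, whether the lower number follows from the presence of the primary amine or from the loss of the propoxy chain stays open. A hydroxyl group or a dimethylamino group on the same saturated chain carbon would separate these two readings.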